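This account rests on a few compounds, and the source may have more. Where it says the series, first, only, none or still open, it means among the compounds named here.

Working notes on the series. In a functional assay on HL-60 cells (Homo sapiens) for cytotoxicity, read by WST assay, with a stated time of 48 h (a lower number here means that less compound is needed, a higher number that more compound is needed for the effect), compound 1 (`O=C1OC[C@H](Cc2ccccc2)[C@H]1Cc1ccc(Cl)c(Cl)c1`) stands at 19000 nM while compound 2 (`COc1ccccc1C[C@H]1COC(=O)[C@@H]1Cc1ccc(Cl)c(Cl)c1`) stands at 14000 nM and compound 3 (`CCCCOc1ccccc1C[C@H]1COC(=O)[C@@H]1Cc1ccc(Cl)c(Cl)c1`) stands at 10000 nM on the same read-out. Compound 3 is not separated from either of the other two, since the measured steps to it are a 1.9-fold lower number from compound 1 to compound 3 (0.28 log units; within the scatter) and a 1.4-fold lower number from compound 2 to compound 3 (0.15 log units; within the scatter) and both stay within the scatter.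

The next comparison is compound 4 (`Cc1ccccc1C[C@H]1COC(=O)[C@@H]1Cc1ccc(Cl)c(Cl)c1`). The change is methyl in place of butoxy on an aromatic carbon and amounts to methyl in place of butoxy on an aromatic carbon, ortho to a large group. No methyl compound has been measured, so the guides are the steps among the three alkoxy and unsubstituted compounds: a 1.4-fold lower number from compound 1 to compound 2 (0.13 log units; within the scatter) for methoxy in place of hydrogen, the butoxy step given above, and the propyl extension of the chain, also given above. None of these three compounds departs from the others beyond the scatter in this assay and nothing in them points to a large effect at this carbon.

The expected step is a 1.4-fold higher number from compound 3 to compound 4 (0.15 log units; within the scatter) and no change beyond the scatter is expected. For compound 4 the estimated value is 14000 nM with an expected range from 7000 nM to 28000 nM in this read-out.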

Compound 4, half-maximal effective concentration: 22000 nM
Estimate against measurement, compound 4: 1.6-fold (0.20 log units) below, and the stated range covers the measured number.
By their numbers in this assay, from the lowest: compounds 3, 2, 1 and 4 (each within the scatter of the next, the first and the last beyond it).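

In this assay, among these compounds, methyl in place of butoxy on this aromatic carbon gives the first step that lies beyond the scatter, though a modest one (a 2.2-fold higher number from compound 3 to compound 4 (0.34 log units; beyond the scatter)). The same methyl compound is not separated from the methoxy compound (a 1.6-fold higher number from compound 2 to compound 4 (0.20 log units; within the scatter)) or from the unsubstituted compound (a 1.2-fold higher number from compound 1 to compound 4 (0.06 log units; within the scatter)), so the only separation among the four compounds is between the butoxy and methyl compounds, and the series does not divide into distinct groups at this carbon. The data shown offer no information on the origin of this step.

Open is whether a chain longer than butoxy, such as hexyloxy, would extend the separation from the methyl compound or leave the number within the scatter of the compounds shown. Also open, from the compounds shown here alone, is how this carbon would respond to a group of a different kind, such as an amine or a carboxylic acid, and whether the butoxy to methyl step would hold on other carbons of the same ring.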